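The source may hold more compounds than are shown below. What is called first, only, known or untested is meant among the compounds shown, and "the series" means these compounds.

Measured so far:
compound 1, `CSc1ccccc1N1CCN(CCCCC(=O)N2CCC[C@H]2C(N)=O)CC1`, 163 nM;
compound 2, `COc1ccccc1N1CCN(CCCCC(=O)N2CCC[C@H]2C(N)=O)CC1`, 634 nM.

For the measured compounds named here, in an assay on HEK293 cells for displacement of a labelled ligand from 5-hydroxytryptamine receptor 7 (Homo sapiens), with a stated time of 1 h (on this read-out lower numbers stand for stronger inhibition and higher numbers for weaker inhibition), compound 2 gives the highest of the two numbers; the only other compound, compound 1, sits at a lower number, and the step of a 3.9-fold higher number from compound 1 to compound 2 (0.59 log units; beyond the scatter) lies beyond the scatter. Compound 3, `NC(=O)[C@@H]1CCCN1C(=O)CCCCN1CCN(c2noc3ccccc23)CC1`, differs from compound 2 by a group of 9 heavy atoms (7 carbon, 1 nitrogen, 1 oxygen; one five-membered aromatic ring with 2 hetero atoms, one six-membered aromatic ring of carbon only) in place of a group of 8 heavy atoms (7 carbon, 1 oxygen; one six-membered aromatic ring of carbon only), on an amine nitrogen in a ring. Going by the values given here, no measured step concerns this change; the one step known, from compound 1 to compound 2, exchanges a single group on the aromatic ring and says nothing about replacing the whole aryl group. The estimate for compound 3 is therefore wide: an expected 300 nM (range 60 nM to 1500 nM), which would mean an expected step of a 2.1-fold lower number from compound 2 to compound 3 (0.32 log units; beyond the scatter).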

Compound 3, inhibition constant: 108 nM
The estimate for compound 3 lay 2.8-fold (0.44 log units) above the measured number; measured number inside the range.
By their numbers in this assay, from the lowest: compounds 3 and 1 (each within the scatter of the next); then compound 2.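

In this assay, exchanging the whole 2-methoxyphenyl group on the ring amine nitrogen for the two-ring group gives a 5.9-fold lower number from compound 2 to compound 3 (0.77 log units; beyond the scatter), so this position accepts more than a single six-membered aromatic ring. The step of a 1.5-fold lower number from compound 1 to compound 3 (0.18 log units; within the scatter) lies within the scatter, so the two-ring group and the methylsulfanyl-bearing aryl group of compound 1 cannot be told apart here. No evidence at hand bears on this result. From the compounds shown here alone, it remains open whether the nitrogen and oxygen of the five-membered ring matter, and how a naphthyl group, with two rings of carbon only, would compare.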